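Removing the Carbamoylamino Arm from Compound 3

The source may report more compounds than this note shows. Statements on the series, on what has been measured and on what is new or still open speak of the compounds shown alone.

In a functional assay on L1210 cells (Mus musculus) for inhibition, read by MTT assay, with a stated time of 72 h (a lower number here means a stronger inhibitor, a higher number a weaker inhibitor), compound 3 (`COc1cc(NC(C)CCCNC(=O)NNC(=O)Nc2ccc(Br)cc2)c2ncccc2c1`) reads 51000 nM and is the weakest of the three measured inhibitors. Compound 1 (`COc1cc(NC(C)CCCNC(=O)Nc2cccc(Cl)c2)c2ncccc2c1`) gives 17000 nM and compound 2 (`COc1cc(NC(C)CCCNC(=O)NNC(=O)Nc2ccc(C(F)(F)F)cc2)c2ncccc2c1`) gives 18000 nM on the same scale.

The next compound is compound 4 (`COc1cc(NC(C)CCCNC(=O)Nc2cccc(C(F)(F)F)c2)c2ncccc2c1`), which carries 3-(trifluoromethyl)phenyl in place of ((4-bromophenyl)carbamoyl)amino on an amide-type nitrogen. The change is 3-(trifluoromethyl)phenyl in place of ((4-bromophenyl)carbamoyl)amino on an amide-type nitrogen and the rest of the structure stays the same.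

Among the measured compounds shown here, two measured steps bear on this exchange. The closer one is a 3.0-fold higher number from compound 1 to compound 3 (0.48 log units; beyond the scatter) and it is the same kind of exchange run in reverse, with 3-chlorophenyl on that nitrogen where compound 4 has 3-(trifluoromethyl)phenyl. The other is a 2.8-fold higher number from compound 2 to compound 3 (0.45 log units; beyond the scatter) for bromo in place of trifluoromethyl on an aromatic carbon, with the carbamoylamino arm retained. Both steps are modest, and both leave compound 3 with the higher number.

A modest step towards a lower number is therefore expected, estimated as a 3.2-fold lower number from compound 3 to compound 4 (0.50 log units; beyond the scatter) in this assay. Compound 4 is expected at 16000 nM within a range of 7000 nM to 35000 nM on this estimate.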

Compound 4, half-maximal inhibitory concentration: 9200 nM
For compound 4 the middle estimate is 1.7-fold (0.24 log units) above the measured one; the range from low to high includes it.
By their numbers in this assay, from the lowest: compounds 4, 1 and 2 (each within the scatter of the next); then compound 3.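

In this assay, replacing the whole ((4-bromophenyl)carbamoyl)amino arm on the amide-type nitrogen with 3-(trifluoromethyl)phenyl gives a 5.5-fold lower number from compound 3 to compound 4 (0.74 log units; beyond the scatter), a modest step that shows the shorter 3-substituted phenyl group is compatible with a lower number at this position. The new pair with the same short arm adds a finding about the aromatic substituent: trifluoromethyl in place of chloro gives a 1.8-fold lower number from compound 1 to compound 4 (0.27 log units; within the scatter), which lies within the scatter, so compound 1 and compound 4 cannot be told apart here. Nothing measured on these compounds accounts for either step.

The exchange from compound 3 to compound 4 removes the carbamoylamino arm and alters the aromatic substituent in one move, so the compounds shown do not separate the contribution of the arm from that of the bromo and trifluoromethyl groups. From the compounds shown here alone, it also remains open how the number would respond to an amine or a carboxylic acid in place of trifluoromethyl on the aromatic carbon, or to a longer chain on the amide-type nitrogen.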